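Fluoro to Methyl on the Amide's Aromatic Ring

This account rests on a few compounds, and the source may have more. Where it says the series, first, only, none or still open, it means among the compounds named here.

Three compounds built on one shared core, a ring bearing two hydroxyls joined to an unsaturated chain, were tested in an ADME assay on S2 cells (Drosophila melanogaster) for cytotoxicity, read by MTT assay; on this read-out lower numbers stand for an effect already at smaller amounts and higher numbers for an effect only at larger amounts of compound. Compound 1, `COC(=O)/C=C/[C@H]1C[C@@H](O)[C@@H](O)C1`, ends in a methyl ester. In this assay compound 1 reaches only the limit of the test, > 350000 nM. Compound 2, `O=C(/C=C/[C@H]1C[C@@H](O)[C@@H](O)C1)Nc1ccc(Cl)cc1`, replaces the ester with an amide to an aromatic ring that carries chloro. For compound 2 the read-out in this assay is again a limit, > 180000 nM. Compound 3, `O=C(/C=C/[C@H]1C[C@@H](O)[C@@H](O)C1)Nc1ccc(F)cc1`, has fluoro in place of chloro on an aromatic carbon. In this assay compound 3 likewise gives only a limit, > 180000 nM. With both ends at limits, the step that the two limits leave unreadable from compound 2 to compound 3 has no readable size. Within the data shown here, two of the three values sit at the limit of > 180000 nM in this assay, at which 2 of the 3 values shown sit, and one at the limit of > 350000 nM in this assay, at which 1 of the 3 values shown sits; no compound so far shows a measurable effect on the cells.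

Compound 4, `Cc1ccc(NC(=O)/C=C/[C@H]2C[C@@H](O)[C@@H](O)C2)cc1`, differs from compound 3 by methyl in place of fluoro on an aromatic carbon. Among the measured compounds shown here, no measured step with a readable size bears on this change; the only guide is that every compound so far stayed at a limit. Compound 4 is therefore expected to give about 300000 nM, estimated between 150000 nM and 1000000 nM. The expected step that the limit leaves unreadable from compound 3 to compound 4 means no change beyond the scatter, most likely another limit.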

Compound 4, half-maximal effective concentration: > 190000 nM
Compound 4: only a limit was reported; the forecaster's own chance of this, stated with the estimate: 85%; the middle value does not contradict the limit.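

In this assay compound 4 also gives only a limit, > 190000 nM. No new step can be read, since the comparisons of compound 4 with compound 2 and compound 3 have limits on both sides. The compounds shown leave open at what concentration, if any, these compounds affect the cells, and whether swapping the aromatic ring's group matters.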